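Bromobenzyl ether series: step from compound 3 to compound 4

The compounds below may be only part of what the source reports. "The series", "measured", "known", "first", "only" and "open" are said of these compounds alone.

Three compounds of the series have numbers in an assay on CHO-K1 cells for displacement of a labelled ligand from prostaglandin E2 receptor EP1 subtype (Homo sapiens); a higher number here means a weaker inhibitor, a lower number a stronger inhibitor. Compound 1 `O=C(O)c1nn(Cc2cc(Br)ccc2OCc2ccccc2)cc1CO` gives 676 nM. For the measured compounds named here, compound 2 `O=C(O)c1nn(Cc2cc(Br)ccc2OCc2ccccc2)cc1C(F)(F)F` gives 2570 nM; the single step measured, a 3.8-fold higher number from compound 1 to compound 2 (0.58 log units; beyond the scatter), concerns a group on the shared core. Compound 3 `Cc1cc(C(=O)O)nn1Cc1cc(Br)ccc1OCc1ccc(F)cc1F` gives 0.525 nM, the lowest of the three numbers, beyond the scatter from both compound 1 and compound 2.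

Compound 4 `Cc1cc(C(=O)O)nn1Cc1cc(Br)ccc1OCc1cccc(Br)c1` is not yet measured. It differs from compound 3 in one place: 3-bromophenyl in place of 2,4-difluorophenyl on a saturated chain carbon bound to an oxygen on an aromatic ring. The rest of compound 3 is kept. Going by the values given here, no measured step touches this part of the molecule; the only step available sits on the core and so gives no guidance on the change here. With nothing to show how the benzyl ether aryl affects this assay, the expected step is a 2.9-fold higher number from compound 3 to compound 4 (0.46 log units; beyond the scatter), within the scatter or modestly beyond it, direction uncertain. The estimate for compound 4 in this assay is 1.5 nM, range 0.3 nM to 8 nM.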

Compound 4, half-maximal inhibitory concentration: 17.8 nM
Beside the measured number, compound 4's estimate is 12-fold (1.07 log units) below it; measured number above the stated range.
By their numbers in this assay, from the lowest: compound 3; then compound 4; then compound 1; then compound 2.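

In this assay, for the compounds shown here, the aryl group on the saturated chain carbon bound to an oxygen on an aromatic ring proves to be a strong determinant of the number: 3-bromophenyl in place of 2,4-difluorophenyl gives a 34-fold higher number from compound 3 to compound 4 (1.53 log units; beyond the scatter) and is graded large, whereas the only earlier step, a 3.8-fold higher number from compound 1 to compound 2 (0.58 log units; beyond the scatter) on the shared core, is graded modest. This position therefore responds to the aryl substitution, and 2,4-difluorophenyl is the better of the two groups compared here. Nothing measured accounts for the size of this step.

The swap removes both fluorines and adds a bromine at once, so the contribution of each remains unresolved. Also open, as far as these compounds go, is how a methoxy or nitrile group on the same phenyl ring would read in this assay and whether the step carries over to the core of compound 1.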